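Swapping the Aromatic End of a Thiosemicarbazone

The compounds below may be only part of what the source reports. "The series", "measured", "known", "first", "only" and "open" are said of these compounds alone.

Among the compounds with values here, in a functional assay on UACC-62 cells (Homo sapiens) for cytotoxicity, read by sulforhodamine B assay (a higher number here means that more compound is tolerated, a lower number that less compound is tolerated), compound 1 `COc1ccc(/C=N\NC(=S)NC(C)(C)CCC[C@](C)(O)[C@@H]2CC=C(C)CC2)cc1` gives 48500 nM, the only exact number so far. Compound 2 `CC1=CC[C@@H]([C@@](C)(O)CCCC(C)(C)NC(=S)N/N=C\c2ccc(N(C)C)cc2)CC1` reads > 100000 nM, which is a limit of the assay and not a number. Within the data shown here, the single measured step is an at least 2.0-fold higher number from compound 1 to compound 2 (0.31 log units; beyond the scatter), with dimethylamino in place of methoxy on an aromatic carbon, and it lies beyond the scatter. Compound 3 `CC1=CC[C@@H]([C@@](C)(O)CCCC(C)(C)NC(=S)N/N=C\c2cccc(Cl)c2)CC1` keeps the shared core but changes its aromatic end: 3-chlorophenyl in place of 4-methoxyphenyl on a carbon with a double bond to nitrogen. Like compound 2, it loses the methoxy, but a different group enters, so the measured step is only a loose guide and gives no firm direction. The estimated change in this assay is a 1.2-fold lower number from compound 1 to compound 3 (0.08 log units; within the scatter), so no shift beyond the scatter is expected. Compound 3 is estimated at 40000 nM, with an expected range of 15000 nM to 100000 nM.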

Compound 3, concentration lethal to 50% of the cells: 42700 nM
Compound 3: the middle estimate sits 1.1-fold (0.03 log units) below what was measured; the range from low to high includes it.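

The new result shows that this aromatic end can change without a clear effect in this assay: a 1.1-fold lower number from compound 1 to compound 3 (0.06 log units; within the scatter) is a step within the scatter, so 4-methoxyphenyl and 3-chlorophenyl cannot be told apart here. Compound 3 also gives compound 2 a second comparison, and an at least 2.3-fold lower number from compound 2 to compound 3 (0.36 log units; beyond the scatter) lies beyond the scatter, so 4-(dimethylamino)phenyl now stands apart from two other aromatic ends, not just one. That step has no exact size, because compound 2 stands at a limit and not at a number: (the limit of > 100000 nM in this assay, at which 1 of the 3 values shown sits).

Still open, from the compounds shown here alone, is whether the higher number of compound 2 belongs to the dimethylamino group itself or would also come with a plain amino group or a morpholine. A 4-chlorophenyl end would show whether the chlorine behaves the same way when only its place changes.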